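Working notes on a chain change in compound 2

A few compounds are considered here, and "the series" means these few. Any claim that something is new, unique, unknown or untested is made for them only; others in the source may bear on it.

Measured in an assay on SW1353 cells (Homo sapiens) for inhibition, read by a luciferase reporter, with stated times of 30 min and 8 h; on this read-out lower numbers stand for stronger inhibition and higher numbers for weaker inhibition:
- Compound 1 `O=c1oc2ccccc2n1CCCCCN1CCN(CCCCCn2c(=O)oc3ccccc32)CC1`: 3430 nM
- Compound 2 `O=c1sc2ccccc2n1CCCCCCN1CCN(CCCCCCn2c(=O)sc3ccccc32)CC1`: 410 nM

Of these two numbers, compound 2 holds the lower at 410 nM, and compound 1 lies higher by more than the usual scatter. Among the compounds with values here, the two measured compounds differ in more than one place, so this assay offers no measured step to serve as a guide for a single change.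

The next compound is compound 3 `O=c1sc2ccccc2n1CCCCCCN1CCN(CCCCn2c(=O)sc3ccccc32)CC1`, which departs from compound 2 in one place: a group of 10 heavy atoms (7 carbon, 1 nitrogen, 1 oxygen, 1 sulfur; one five-membered aromatic ring with 2 hetero atoms, one six-membered aromatic ring of carbon only) in place of a group of 12 heavy atoms (9 carbon, 1 nitrogen, 1 oxygen, 1 sulfur; one five-membered aromatic ring with 2 hetero atoms, one six-membered aromatic ring of carbon only), on a saturated chain carbon, four bonds along the chain from an amine nitrogen in a ring. The rest of the structure stays as it is.

Within the data shown here, with no measured step to lean on, the expectation is a small move toward weaker inhibition, possibly none beyond the scatter. The expected step is a 1.7-fold higher number from compound 2 to compound 3 (0.23 log units; within the scatter). The estimate for compound 3 is 700 nM, with an expected range from 250 nM to 2000 nM.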

Compound 3, half-maximal inhibitory concentration: 830 nM
For compound 3 the middle estimate is 1.2-fold (0.07 log units) below the measured one; the range from low to high includes it.
By their numbers in this assay, from the lowest: compound 2; then compound 3; then compound 1.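

In this assay this position now has its first measured single-place step: the group of 10 heavy atoms in place of the group of 12 heavy atoms, on a saturated chain carbon, four bonds along the chain from an amine nitrogen in a ring, gives a 2.0-fold higher number from compound 2 to compound 3 (0.31 log units; beyond the scatter), a modest move toward weaker inhibition. Both groups hold one five-membered aromatic ring with 2 hetero atoms, one six-membered aromatic ring of carbon only and the same count of hydrogen-bond acceptors, so the two differ in carbon count alone, and this one change does not abolish inhibition, with compound 3 still reading 830 nM. Nothing available on this change speaks to why the number moves.

As far as these compounds go, a single step in one direction sets no trend, so it remains open whether a longer chain at this position would lower the number or raise it, and whether the same shortening on the other chain would give a similar step. Also open, from the compounds shown here alone, is how an ether oxygen or an amine within the chain would read, and what replacing the ring sulfur with oxygen does on its own.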